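A few compounds are considered here, and "the series" means these few. Any claim that something is new, unique, unknown or untested is made for them only; others in the source may bear on it.

Of the compounds shown here, two from this series have been measured in an assay on isolated protein for inhibition of DNA topoisomerase 1 (Homo sapiens), with a stated time of 30 min, tested at 100 uM; a lower number here means a weaker effect, a higher number a stronger effect of the compound at the concentration tested. Compound 1, `O=C(CN1CCN(c2cc3c(cc2F)c(=O)c(C(=O)O)cn3C2CC2)CC1)Nc1ccc(C(=O)/C=C/c2ccccc2)cc1`, gives 57.2% there. Compound 2, `O=C(CN1CCN(c2cc3c(cc2F)c(=O)c(C(=O)O)cn3C2CC2)CC1)Nc1ccc(C(=O)/C=C/c2ccc(Cl)cc2)cc1`, gives 67.5% in this assay. For the measured compounds named here, the one step that connects them, a number 10.3 percentage points higher from compound 1 to compound 2 (beyond the scatter), places compound 2 as the higher of the two numbers, with compound 1 as its only neighbour.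

Compound 3, `COc1cc(/C=C/C(=O)c2ccc(NC(=O)CN3CCN(c4cc5c(cc4F)c(=O)c(C(=O)O)cn5C4CC4)CC3)cc2)cc(OC)c1OC`, has not yet been measured. It differs from compound 2 in a single place: 3,4,5-trimethoxyphenyl in place of 4-chlorophenyl on a double-bonded chain carbon bound to a double-bonded chain carbon. Going by the values given here, only the step from compound 1 to compound 2 bears on this change, since it also alters the substituent on the same aromatic ring attached to the double-bonded chain carbon; that step was modest. The change to compound 3 is larger in what leaves and what enters, yet nothing measured shows how the trimethoxy pattern behaves here. Compound 3 is therefore expected to stay near compound 2 in this assay, with a step of a number 5.5 percentage points lower from compound 2 to compound 3 (within the scatter) that may fall within the scatter. For compound 3 the estimate is 62%, with a range from 45% to 78%.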

Compound 3, a percentage reported as inhibition, at one concentration (the size of the read-out at that concentration, not a potency): 67.4%
For compound 3 the middle estimate is 5.4 percentage points below the measured one; the measured number falls inside the stated range.
By their numbers in this assay, from the lowest: compound 1; then compounds 3 and 2 (each within the scatter of the next).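

In this assay, the step to the larger group, a number 0.1 percentage points lower from compound 2 to compound 3 (within the scatter), shows that this place, on a double-bonded chain carbon bound to a double-bonded chain carbon, accepts 3,4,5-trimethoxyphenyl as well as 4-chlorophenyl: the two compounds cannot be told apart, although the entering group has 12 heavy atoms against 7 and 3 hydrogen-bond acceptors against 0. Set against the plain phenyl of compound 1, the trimethoxy group gives a number 10.2 percentage points higher from compound 1 to compound 3 (beyond the scatter), which stands with the earlier a number 10.3 percentage points higher from compound 1 to compound 2 (beyond the scatter), so among these three compounds both substituted rings read apart from the unsubstituted one, and none goes against that. Nothing at hand explains why two such different groups give the same reading.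

The compounds shown leave open whether a single methoxy group on this ring would read like the three together, and whether an amine or a carboxylic acid there would hold the same level. They also leave open whether this level reflects potency, since each reading comes from one concentration only.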